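Amides at the limit, and one urea-type exception

The compounds below may be only part of what the source reports. "The series", "measured", "known", "first", "only" and "open" are said of these compounds alone.

In a functional assay on PC-3 cells (Homo sapiens) for inhibition, read by sulforhodamine B assay, with a stated time of 48 h (on this read-out higher numbers stand for weaker inhibition of growth and lower numbers for stronger inhibition of growth), compound 1 (`COc1cc(-c2nn(-c3cccc(NC(=O)c4cccc(C(F)(F)F)c4)c3)cc2-c2ccncc2)ccc1Cl`) gives > 50000 nM as a limit, not a number. Compound 3 (`COc1cc(-c2nn(-c3cccc(NC(=O)c4ccc(Cl)c(C(F)(F)F)c4)c3)cc2-c2ccncc2)ccc1Cl`) gives > 32500 nM as a limit too, so it offers no number to start from. Compound 2 (`COc1cc(-c2nn(-c3cccc(NC(=O)Nc4cccc(C(F)(F)F)c4)c3)cc2-c2ccncc2)ccc1Cl`) gives 2510 nM as a true number. The large steps of an at least 19-fold lower number from compound 1 to compound 2 (1.29 log units; beyond the scatter) and an at least 12-fold higher number from compound 2 to compound 3 (1.11 log units; beyond the scatter) lie beyond the scatter, while a step that the two limits leave unreadable from compound 1 to compound 3 cannot be read. Compound 4 (`COc1cc(-c2nn(-c3cccc(NC(=O)c4ccccc4)c3)cc2-c2ccncc2)ccc1Cl`) has phenyl in place of 4-chloro-3-(trifluoromethyl)phenyl on a carbonyl carbon. It lacks the (3-(trifluoromethyl)phenyl)amino group that came with an at least 19-fold lower number from compound 1 to compound 2 (1.29 log units; beyond the scatter) and so no step beyond the scatter is expected, the estimate being a step that the limit leaves unreadable from compound 3 to compound 4 in either direction. In this assay compound 4 is expected at 45000 nM with 20000 nM to 100000 nM as the estimated range.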

Compound 4, concentration for total growth inhibition: > 100000 nM
Compound 4: a limit, no number; the forecaster's own chance of this, stated with the estimate: 75%; middle value at least 2.2-fold (0.34 log units) from the limit.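

Compound 4, with plain phenyl on the carbonyl carbon, also ends at a limit and not a number: the limit of > 100000 nM in this assay, at which 1 of the 4 values shown sits. It thus joins compound 1 and compound 3, so none of the three amides gives a number, with or without trifluoromethyl and chloro on the phenyl. The urea-type compound 2 stands well apart, with an at least 39-fold higher number from compound 2 to compound 4 (1.60 log units; beyond the scatter), while the steps among the three amides cannot be read.

Going by these compounds, it stays open whether a urea-type link bearing plain phenyl would still give a number. Also open, on these data alone, is how an amine or a carboxylic acid on the amide phenyl would read.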